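This account rests on a few compounds, and the source may have more. Where it says the series, first, only, none or still open, it means among the compounds named here.

Working notes on the series.

Compound 1 `Cc1cc(C(=O)NCN2CCC(c3cccc[n+]3[O-])CC2)ccc1F` carries a 4-fluoro-3-methylphenyl on the amide. Going by the values given here, in a functional assay on HEK293 cells for agonist activity at D(4) dopamine receptor (Homo sapiens), read by FLIPR (on this read-out lower numbers stand for smaller maximal responses and higher numbers for larger maximal responses), compound 1 gives 67%, the highest of the three numbers measured so far. Compound 2 `Cc1cccc(NC(=O)CN2CCC(c3ccc(O)cc3)CC2)c1` gives 60%, which lies within the scatter of compound 1. Compound 3 `Cc1cccc(NC(=O)CN2CCC(c3ccccc3)CC2)c1` gives 37%, well below compound 1. Among the compounds with values here, the one step that has been measured is a number 23 percentage points lower from compound 2 to compound 3 (beyond the scatter); it concerns the other aromatic ring of the shared core, the one attached to the piperidine, and removes a hydroxy rather than a fluoro, so it bears only loosely on the present question.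

Compound 4 `Cc1cccc(C(=O)NCN2CCC(c3cccc[n+]3[O-])CC2)c1` differs from compound 1 in one place: hydrogen in place of fluoro on an aromatic carbon. Within the data shown here, no measured pair shows this change. Given that the sole comparable step, removal of an aromatic substituent, lowered the maximal response in this assay, a drift downward is the more likely direction, but with a single heavy atom leaving from a different ring, a step beyond the scatter cannot be expected with confidence. The estimated step is a number 7 percentage points lower from compound 1 to compound 4 (within the scatter). For compound 4 the expected value in this assay is 60%, with a range from 42% to 78%.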

Compound 4, largest response reached (reported as efficacy), in percent of the reference or control that the assay uses: 77%
Estimate against measurement, compound 4: 17 percentage points below; low and high end bracket the measured number.
By their numbers in this assay, from the lowest: compound 3; then compounds 2, 1 and 4 (each within the scatter of the next, the first and the last beyond it).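

Going by these compounds alone, this is the first measured pair at this position, and in this assay it gives a number 10 percentage points higher from compound 1 to compound 4 (within the scatter): the change from 4-fluoro-3-methylphenyl to 3-methylphenyl leaves the maximal response within the scatter, so the fluoro is not required for a response of this size in this pair. The loss of an aromatic substituent in the other measured pair, a number 23 percentage points lower from compound 2 to compound 3 (beyond the scatter), concerns a hydroxy on a different aromatic ring, and no such step beyond the scatter appears here, so that result does not carry over to this position. Nothing available accounts for the behaviour of this change.

As far as these compounds go, with one pair at this carbon, it remains open whether a chloro, a methoxy or an amino group para to the large group would keep the response in the same range or move it beyond the scatter. Also open is what the neighbouring methyl group contributes, since a phenyl amide lacking that methyl, or one carrying an ethyl in its place, is not among the compounds shown.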